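All Three Aryl Triazole Analogues Sit at the Assay Limit

The source may hold more compounds than are shown below. What is called first, only, known or untested is meant among the compounds shown, and "the series" means these compounds.

Compound 1 `N#CC1=C(N)Oc2c(c3nc4ccccc4nc3c3ccccc23)C12C(=O)N(Cc1cnnn1-c1ccc(Cl)cc1)c1ccccc12` in a functional assay on MCF7 cells (Homo sapiens) for antiproliferative activity, read by MTT assay, with a stated time of 48 h (a higher number here means a weaker inhibitor, a lower number a stronger inhibitor), gives > 50000 nM, which is a limit of the measurement rather than a number.
Compound 2 `COc1ccccc1-n1nncc1CN1C(=O)C2(C(C#N)=C(N)Oc3c2c2nc4ccccc4nc2c2ccccc32)c2ccccc21` in this assay gives > 50000 nM, again a limit.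
Compound 3 `Cc1ccc(C)c(-n2nncc2CN2C(=O)C3(C(C#N)=C(N)Oc4c3c3nc5ccccc5nc3c3ccccc43)c3ccccc32)c1` in this assay gives > 50000 nM, also a limit.

Compound 3 therefore stands where every measured compound stands: at the limit, with no number of its own. The steps among the measured compounds cannot be sized for the same reason: a step that the two limits leave unreadable from compound 1 to compound 2, a step that the two limits leave unreadable from compound 1 to compound 3 and a step that the two limits leave unreadable from compound 2 to compound 3 are all unreadable, since (the limit of > 50000 nM in this assay, at which 3 of the 3 values shown sit).

Compound 4 `N#CC1=C(N)Oc2c(c3nc4ccccc4nc3c3ccccc23)C12C(=O)N(Cc1cnnn1-c1cc(Cl)ccc1Cl)c1ccccc12` differs from compound 3 only in the group on the aromatic nitrogen: 2,5-dichlorophenyl in place of 2,5-dimethylphenyl on an aromatic nitrogen. Among the measured compounds shown here, changing the group on that nitrogen, from 4-chlorophenyl to 2-methoxyphenyl or 2,5-dimethylphenyl, left every compound at the limit, so no step in this assay beyond the scatter is expected here either. Compound 4 is accordingly expected to give 70000 nM, most likely reported only as a limit, within 20000 nM to 200000 nM, which means an estimated step that the limit leaves unreadable from compound 3 to compound 4.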

Compound 4, half-maximal inhibitory concentration: > 50000 nM
Compound 4: no number, only a limit (the forecaster's own chance of this, stated with the estimate: 85%); the middle value lies beyond the limit too.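

Compound 4 sits at the same limit as compound 1, compound 2 and compound 3, so none of the steps from those compounds to compound 4 can be read: the limit of > 50000 nM in this assay, at which 4 of the 4 values shown sit.

The compounds shown leave open whether any other group on that aromatic nitrogen would give a measurable value in this assay.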